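Ethyl for dimethylamino on the aryl ring: lipophilicity outlook

This account rests on a few compounds, and the source may have more. Where it says the series, first, only, none or still open, it means among the compounds named here.

Measured so far in a physicochemical assay for lipophilicity, at pH 7.4; on this read-out higher numbers stand for higher lipophilicity and lower numbers for lower lipophilicity:
compound 1 `CCc1ccc(N(CC(C)C)S(=O)(=O)c2ccc3c(c2)C(=O)CC(C2CCNCC2)O3)cc1` — 2.21
compound 2 `CCc1ccc(N(CC2CCC2)S(=O)(=O)c2ccc3c(c2)C(=O)CC(C2CCOCC2)O3)cc1` — 4.1
compound 3 `CC(C)CN(c1ccc(N(C)C)cc1)S(=O)(=O)c1ccc2c(c1)C(=O)CC(C1CCOCC1)O2` — 3.6

Compound 3 stands second highest of the three numbers in this assay. Its nearest neighbour is compound 2, whose number is higher by a margin beyond the scatter; the furthest is compound 1, whose number is lower by a margin well beyond the scatter. Among the measured compounds shown here, no pair among the measured compounds differs in a single place, so no measured step can be read off for the change at hand.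

Compound 4 `CCc1ccc(N(CC(C)C)S(=O)(=O)c2ccc3c(c2)C(=O)CC(C2CCOCC2)O3)cc1` is not yet measured. Its difference from compound 3 is ethyl in place of dimethylamino on an aromatic carbon. The group that leaves carries one hydrogen-bond acceptor and the group that enters carries none, so the change is expected to move the number upward, beyond the scatter, rather than leaving it flat.

On that basis the step from compound 3 to compound 4 in this assay is estimated at a number 0.60 log units higher from compound 3 to compound 4 (beyond the scatter). Compound 4 is expected to come in at 4.2, with a range from 3.7 to 4.7, placing it near the number of compound 2.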

Compound 4, distribution coefficient: 4.21
Estimate against measurement, compound 4: 0.01 log units below; the measured number falls inside the stated range.
By their numbers in this assay, from the lowest: compound 1; then compound 3; then compounds 2 and 4 (each within the scatter of the next).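

Notes on the series, in this assay: ethyl in place of dimethylamino on an aromatic carbon, para to a large group, now has a measured single-place step (a number 0.61 log units higher from compound 3 to compound 4 (beyond the scatter)), which the earlier compounds could not supply. Compound 4 also gives single-place readings at two other sites: isopropyl in place of cyclobutyl on a saturated chain carbon bound to a sulfonamide nitrogen (a number 0.11 log units higher from compound 2 to compound 4 (within the scatter)), and oxan-4-yl in place of piperidin-4-yl on a saturated ring carbon (a number 2.00 log units higher from compound 1 to compound 4 (beyond the scatter)), so the aryl step can now be set beside a flat step at the chain and a large one at the saturated ring. No measured evidence bears on why these steps have the sizes they do.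

Only dimethylamino and ethyl are shown at this aromatic carbon, so the readings for a methoxy group, a chlorine atom, a propyl chain or a carboxylic acid there remain open. Also open, going by these compounds, is whether the step from dimethylamino to ethyl keeps its size with piperidin-4-yl in place of oxan-4-yl or with cyclobutyl in place of isopropyl.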